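From 2-methoxyethoxy to cyclopropylamino on the shared core

This account rests on a few compounds, and the source may have more. Where it says the series, first, only, none or still open, it means among the compounds named here.

In an ADME assay on HFF cells (Homo sapiens) for cytotoxicity, with a stated time of 8 days (a higher number here means that more compound is tolerated, a lower number that less compound is tolerated), compound 2 (`COCCOc1nc(N)nc2c1ncn2/C=C1/CC1(CO)CO`) gives only a limit, > 300000 nM. Compound 3 (`CCCCCCCCOc1nc(N)nc2c1ncn2/C=C1/CC1(CO)CO`) also gives only a limit, > 300000 nM. Compound 2 therefore stands at the limit of > 300000 nM in this assay, at which 2 of the 3 values shown sit. Among the measured compounds shown here, compound 1 (`CNc1nc(N)nc2c1ncn2/C=C1/CC1(CO)CO`) is the only one with a number, 265000 nM.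

Compound 4 (`Nc1nc(NC2CC2)c2ncn(/C=C3/CC3(CO)CO)c2n1`) has cyclopropylamino in place of 2-methoxyethoxy on an aromatic carbon. For the measured compounds named here, two measured steps bear on this change, and both start from the methylamino group of compound 1. They are an at least 1.1-fold higher number from compound 1 to compound 2 (0.05 log units; that floor lies within the scatter) and an at least 1.1-fold higher number from compound 1 to compound 3 (0.05 log units; that floor lies within the scatter). The third gives no size, being a step that the two limits leave unreadable from compound 2 to compound 3.

Compound 4 also carries an amino link at this place, and the expectation rests on compound 1 with its 265000 nM. A small move to a lower number is therefore expected, with no clear step beyond the scatter. The estimate corresponds to an at least 1.3-fold lower number from compound 2 to compound 4 (0.13 log units; that floor lies within the scatter). Compound 4 is expected at 220000 nM, with an estimated range of 80000 nM to 300000 nM.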

Compound 4, half-maximal cytotoxic concentration: > 300000 nM
Compound 4 ended at the assay's limit; the forecaster's own chance of this, stated with the estimate: 40%; middle value at least 1.3-fold (0.13 log units) from the limit.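

In this assay, compound 4 shows that an amino link at this place can also reach the limit, which until now was held only by the oxygen-linked groups of compound 2 and compound 3: the limit of > 300000 nM in this assay, at which 3 of the 4 values shown sit.

Cyclopropyl in place of methyl on the nitrogen gives an at least 1.1-fold higher number from compound 1 to compound 4 (0.05 log units; that floor lies within the scatter), so this change shows no clear step. The steps among the compounds that stand at the limit cannot be read.

From the compounds shown here alone, it remains open whether a longer chain on the nitrogen, a morpholine or a carboxylic acid at this place would give a number clearly under the limit. Also open, going by these compounds, is how far past the limit compound 2, compound 3 and compound 4 lie, and so whether these groups differ at all in this assay.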